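The source may report more compounds than this note shows. Statements on the series, on what has been measured and on what is new or still open speak of the compounds shown alone.

Measured in a functional assay on B16-F0 cells (Mus musculus) for inhibition, read by CCK-8 assay, with a stated time of 48 h; on this read-out higher numbers stand for weaker inhibition and lower numbers for stronger inhibition:
- compound 1 `COc1cc(-c2ccnc3cc(-c4ccc(C)c(C)c4)nn23)cc(OC)c1OC`: 391 nM
- compound 2 `COc1cc(-c2ccnc3cc(-c4cn(C)c5ccccc45)nn23)cc(OC)c1OC`: 185 nM

Compound 2, at 185 nM, has the lower of the two numbers, and so the stronger inhibition. The next compound, compound 3 `C=Cc1ccc(-c2cc3nccc(-c4cc(OC)c(OC)c(OC)c4)n3n2)cc1`, has not yet been measured. It carries 4-vinylphenyl in place of 1-methyl-1H-indol-3-yl on an aromatic carbon.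

Going by the values given here, only one measured step bears on this change: a 2.1-fold lower number from compound 1 to compound 2 (0.33 log units; beyond the scatter). That modest step put 1-methyl-1H-indol-3-yl in place of 3,4-dimethylphenyl on the same aromatic carbon. Compound 3 again has a phenyl group there, as compound 1 does at 391 nM, so a return towards that number seems likely, though one step is thin evidence. The expected change in this assay is modest and towards a higher number: a 1.6-fold higher number from compound 2 to compound 3 (0.20 log units; within the scatter). For compound 3 the estimate is 290 nM, with an expected range of 100 nM to 850 nM.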

Compound 3, half-maximal inhibitory concentration: 788 nM
Compound 3: the middle estimate sits 2.7-fold (0.43 log units) below what was measured, and the stated range covers the measured number.
By their numbers in this assay, from the lowest: compound 2; then compounds 1 and 3 (each within the scatter of the next).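

In this assay, 4-vinylphenyl in place of 1-methyl-1H-indol-3-yl on this aromatic carbon gives a 4.3-fold higher number from compound 2 to compound 3 (0.63 log units; beyond the scatter), so the lower number of compound 2 now holds against two different phenyl groups, not just 3,4-dimethylphenyl. The two phenyl compounds show a 2.0-fold higher number from compound 1 to compound 3 (0.30 log units; within the scatter), which means that this assay does not separate 4-vinylphenyl from 3,4-dimethylphenyl. Nothing available here explains why 1-methyl-1H-indol-3-yl gives the lowest number of the three.

Still open, on these data alone, is whether the ring nitrogen with its methyl or the second aromatic ring of 1-methyl-1H-indol-3-yl matters more, which a naphthyl group at this carbon could help to separate. Also open, as far as these compounds go, is how an amine, a carboxylic acid or a longer chain on the phenyl ring would read in this assay at this position.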